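This account rests on a few compounds, and the source may have more. Where it says the series, first, only, none or still open, it means among the compounds named here.

Compound 1 `CCOC(=O)C1=C(C)N/C(=C/c2cc(C)n(Cc3ccc(C(F)(F)F)cc3)c2C)C1=O`: 100 mL.min-1.g-1
Compound 2 `CC1=C(C(=O)OC(C)(C)C)C(=O)/C(=C\c2cc(C)n(-c3ccccc3C(F)(F)F)c2C)N1`: 86 mL.min-1.g-1

Both numbers come from an ADME assay on microsomes from liver (Mus musculus) for metabolic stability, read by LC-MS, tested at 1 uM; a higher number here means faster removal of the compound, a lower number slower removal. Compound 2 has the smaller of the two, but its gap to compound 1 is within the scatter, so the pair cannot be told apart. Compound 3 `CC1=C(C(=O)OCc2ccccc2)C(=O)/C(=C\c2cc(C)n(-c3ccccc3C(F)(F)F)c2C)N1` differs from compound 2 in a single place: benzyl in place of tert-butyl on an oxygen next to a carbonyl group. Going by the values given here, no measured pair shows this change, so the expected step of a 1.3-fold higher number from compound 2 to compound 3 (0.11 log units; within the scatter) is small, in either direction or none beyond the scatter. Compound 3 is therefore estimated at 110 mL.min-1.g-1, with a range from 55 mL.min-1.g-1 to 220 mL.min-1.g-1, because compound 2 gives 86 mL.min-1.g-1.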

Compound 3, intrinsic clearance in microsomes: 560 mL.min-1.g-1
Estimate against measurement, compound 3: 5.1-fold (0.71 log units) below; measured number outside the range, above it.
By their numbers in this assay, from the lowest: compounds 2 and 1 (each within the scatter of the next); then compound 3.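

At this place, what sits on the oxygen matters: in this assay, benzyl in place of tert-butyl gives a 6.5-fold higher number from compound 2 to compound 3 (0.81 log units; beyond the scatter), a shift that the earlier pair, compound 1 and compound 2, gave no sign of. Removal of the compound in this test therefore depends on this one group, though a single pair shows this only for this core. No measurement shown here gives a reason for the step.

On these data alone, whether methyl, or a benzyl carrying a fluorine on its ring, would stay close to compound 2 or climb towards compound 3 remains open. So does whether the same change behaves alike on the core of compound 1.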